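The source may report more compounds than this note shows. Statements on the series, on what has been measured and on what is new or still open speak of the compounds shown alone.

Compounds measured so far:

Compound 1, `O=C(Nc1ccc(Oc2ccnc3[nH]ccc23)cc1)c1ccc(-c2ccc(F)cc2F)cn1` — in a functional assay on PC-3 cells (Homo sapiens) for cytotoxicity, read by MTT assay, with a stated time of 72 h (a higher number here means a weaker inhibitor, a lower number a stronger inhibitor), compound 1 gives > 10000 nM, which is a limit of the assay rather than a number.
Compound 2, `COc1ccc(-c2ccc(C(=O)Nc3ccc(Oc4ccnc5[nH]ccc45)c(F)c3)nc2)cc1` — compound 2 gives 650 nM.
Compound 3, `O=C(Nc1ccc(Oc2ccnc3[nH]ccc23)c(F)c1)c1ccc(-c2ccc(Cl)cc2)cn1` — compound 3 gives 3030 nM.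

Among the two numbers, compound 3 stands highest: the only measured step, a 4.7-fold higher number from compound 2 to compound 3 (0.67 log units; beyond the scatter), shows the chloro analogue giving a weaker result than the methoxy analogue. Compound 4, `O=C(Nc1ccc(Oc2ccnc3[nH]ccc23)c(F)c1)c1ccc(-c2ccc(F)cc2F)cn1`, differs from compound 3 by 2,4-difluorophenyl in place of 4-chlorophenyl on an aromatic carbon. Among the measured compounds shown here, no measured step mirrors this exact exchange, so the expectation rests on what the values show. Compound 1 carries the same 2,4-difluorophenyl group, and in this assay compound 1 reached only a limit, (the limit of > 10000 nM in this assay, at which 1 of the 3 values shown sits). Compound 3, with 4-chlorophenyl, already gives the weaker of the two numbers. Compound 4 is therefore expected to give a step of a 2.3-fold higher number from compound 3 to compound 4 (0.36 log units; beyond the scatter), toward a weaker result. The estimate for compound 4 is 7000 nM, within a range from 2500 nM to 20000 nM.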

Compound 4, half-maximal inhibitory concentration: 4720 nM
The estimate for compound 4 lay 1.5-fold (0.17 log units) above the measured number, and the stated range covers the measured number.
By their numbers in this assay, from the lowest: compound 2; then compounds 3 and 4 (each within the scatter of the next). At a limit, above all of these: compound 1.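

Exchanging 4-chlorophenyl for 2,4-difluorophenyl, on the aromatic carbon two atoms from the ring nitrogen, gives a 1.6-fold higher number from compound 3 to compound 4 (0.19 log units; within the scatter), so this assay does not tell these two groups apart, while the 4-methoxyphenyl group still holds the lower number, with a 7.3-fold higher number from compound 2 to compound 4 (0.86 log units; beyond the scatter). With 2,4-difluorophenyl held fixed, a fluoro in place of hydrogen elsewhere in the molecule gives an at least 2.1-fold lower number from compound 1 to compound 4 (0.32 log units; beyond the scatter), the first sign that a change away from this position also counts. Compound 1 stands at a limit of the assay, not at a number, so this step has only one bound: the limit of > 10000 nM in this assay, at which 1 of the 4 values shown sits.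

On these data alone, it remains open whether the lower number belongs to 4-methoxyphenyl alone or would also come with a hydroxy or a dimethylamino group on that phenyl ring. As far as these compounds go, it is also open whether the fluoro step holds with 4-methoxyphenyl in place.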